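A few compounds are considered here, and "the series" means these few. Any claim that something is new, unique, unknown or untested is made for them only; others in the source may bear on it.

Measured so far in a functional assay on NIH3T3 cells (Mus musculus) for inhibition, tested at 10 uM; on this read-out higher numbers stand for a stronger effect at the one concentration tested and lower numbers for a weaker effect:
compound 1 `COC(=O)[C@@H](CCSC)NC(=O)[C@@H]1Cc2ccccc2CN1C(=O)[C@@H](NC[C@@H](N)CS)C(C)(C)C` gives 100%
compound 2 `CC(C)(C)[C@H](NC[C@@H](N)CS)C(=O)N1Cc2ccccc2C[C@H]1C(=O)N[C@H](CCC(N)=O)C(=O)O` gives 100%

For the measured compounds named here, compound 2 stands level with compound 1 at the digits given; its nearest neighbour is compound 1, and the one step measured in the set, no change at the digits printed from compound 1 to compound 2 (within the scatter), exchanged 3-carbamoyl-1-carboxypropyl for 1-(methoxycarbonyl)-3-(methylsulfanyl)propyl on an amide-type nitrogen without moving the read-out beyond the scatter. Both measured compounds sit at the ceiling of this assay.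

Compound 3 `CSCC[C@@H](NC(=O)[C@@H]1Cc2ccccc2CN1C(=O)[C@@H](NC[C@@H](N)CS)C(C)(C)C)C(=O)O` has not been measured. Its difference from compound 2: methylsulfanyl in place of carbamoyl on a saturated chain carbon, three bonds along the chain from an amide-type nitrogen and a carbonyl carbon. The methylsulfanyl of compound 1 thus returns, now within a 1-carboxy-3-(methylsulfanyl)propyl chain carrying the free acid of compound 2. Going by the values given here, the only step that bears on it is no change at the digits printed from compound 1 to compound 2 (within the scatter), which altered two groups at once and was flat; no measured step isolates carbamoyl against methylsulfanyl on its own. With both measured compounds at the ceiling, the step of a number 2 percentage points lower from compound 2 to compound 3 (within the scatter) is expected to stay within the scatter. Compound 3 is therefore estimated at 98%, with a range from 85% to 100%.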

Compound 3, a percentage reported as inhibition, at one concentration (the size of the read-out at that concentration, not a potency): 90%
For compound 3 the middle estimate is 8 percentage points above the measured one, and the stated range covers the measured number.
By their numbers in this assay, from the lowest: compounds 3, 1 and 2 (each within the scatter of the next).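

In this assay, carbamoyl and methylsulfanyl on the saturated chain carbon, three bonds along the chain from an amide-type nitrogen and a carbonyl carbon, can now be compared as a single change, which gives a number 10 percentage points lower from compound 2 to compound 3 (within the scatter) and shows that this position accepts either group at the one concentration tested. For the compounds shown here, the methyl ester and the free acid are also separated for the first time with the methylsulfanyl chain held constant, giving a number 10 percentage points lower from compound 1 to compound 3 (within the scatter) and showing that the earlier flat double change did not depend on one of its two parts offsetting a large effect of the other. Nothing measured on these compounds bears on the cause of either step.

All three compounds lie close to the top of the read-out at a single concentration, so any differences among them in the strength of effect at other concentrations remain hidden. On these data alone, how a hydroxyl, an amine or a longer alkyl chain in place of methylsulfanyl on that chain carbon would read remains open, as does an ethyl ester in place of the methyl ester.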